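Amine tail swap on a diaryl-urea triazole series

A few compounds are considered here, and "the series" means these few. Any claim that something is new, unique, unknown or untested is made for them only; others in the source may bear on it.

Measured so far:
compound 1 `CCN(CC)CCn1cnnc1-c1cc(Oc2ccc(NC(=O)Nc3ccccc3C(F)(F)F)cc2F)ccn1` — 11600 nM
compound 2 `CCN(CC)CCn1cnnc1-c1cc(Oc2ccc(NC(=O)Nc3ccc(F)c(F)c3)cc2F)ccn1` — 41300 nM
compound 3 `CCN(CC)CCn1cnnc1-c1cc(Oc2ccc(NC(=O)Nc3ccc(F)c(Cl)c3)cc2F)ccn1` — 34000 nM

In a functional assay on MDA-MB-231 cells (Homo sapiens) for antiproliferative activity, read by MTT assay, with a stated time of 72 h (on this read-out higher numbers stand for weaker inhibition and lower numbers for stronger inhibition), compound 2 gives the highest of the three numbers. Its nearest neighbour is compound 3, with a 1.2-fold lower number from compound 2 to compound 3 (0.08 log units; within the scatter), a gap within the scatter, and its furthest is compound 1, with a 3.6-fold higher number from compound 1 to compound 2 (0.55 log units; beyond the scatter). The step from compound 1 to compound 3 is a 2.9-fold higher number from compound 1 to compound 3 (0.47 log units; beyond the scatter).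

Compound 4 `CN(C)CCCn1cnnc1-c1cc(Oc2ccc(NC(=O)Nc3ccc(F)c(F)c3)cc2F)ccn1` differs from compound 2 only in the tail on the triazole: (dimethylamino)methyl in place of diethylamino on a saturated chain carbon, two bonds along the chain from an aromatic nitrogen. Going by the values given here, none of the measured steps touches this tail; all three concern the aryl urea. There is therefore no measured guide, and no step beyond the scatter is expected in this assay. Compound 4 is estimated at 40000 nM, between 13000 nM and 120000 nM, a step of a 1.0-fold lower number from compound 2 to compound 4 (0.01 log units; within the scatter).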

Compound 4, half-maximal inhibitory concentration: 25300 nM
Compound 4: middle estimate off by 1.6-fold (0.20 log units), on the high side; the measured number falls inside the stated range.
By their numbers in this assay, from the lowest: compound 1; then compounds 4, 3 and 2 (each within the scatter of the next).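

Across the tail, this assay gives a 1.6-fold lower number from compound 2 to compound 4 (0.21 log units; within the scatter), the only step shown that touches this part of the molecule. Replacing 2-(diethylamino)ethyl with 3-(dimethylamino)propyl on the aromatic nitrogen therefore leaves the read-out within the scatter, at least alongside the 3,4-difluorophenyl urea. Nothing available explains this result.

From the compounds shown here alone, it remains open whether a morpholine or piperidine at the chain end, or a longer chain, would also stay within the scatter. Going by these compounds, the same tail change also remains untested beside the 2-(trifluoromethyl)phenyl urea of compound 1.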